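Chloro for methoxy on the aryl of a hydroxy-methoxy chalcone

This account rests on a few compounds, and the source may have more. Where it says the series, first, only, none or still open, it means among the compounds named here.

Measured compounds:
compound 1, `O=C(/C=C/c1cccc(O)c1)c1cccc(-n2cc(-c3ccc(Cl)cc3)[nH]c2=O)c1`, 1510 nM
compound 2, `COc1ccc(-c2cn(-c3cccc(C(=O)/C=C/c4ccc(O)c(OC)c4)c3)c(=O)[nH]2)cc1`, 5850 nM

Both compounds were tested in a functional assay on RXF 393 cells (Homo sapiens) for inhibition; on this read-out lower numbers stand for stronger inhibition of growth and higher numbers for weaker inhibition of growth. Within the data shown here, compound 2 stands at the higher of the two numbers, and compound 1, the only other measured compound, sits at a lower number, a gap beyond the scatter of repeated measurements. Among the measured compounds shown here, compound 1 and compound 2 differ in two places at once, so no single structural step between them can be read off.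

Compound 3, `COc1cc(/C=C/C(=O)c2cccc(-n3cc(-c4ccc(Cl)cc4)[nH]c3=O)c2)ccc1O`, has not yet been measured. It follows from compound 2 by a single change: chloro in place of methoxy on an aromatic carbon. The same pairing of chloro with a lower number in this assay than methoxy is seen between compound 1 and compound 2, but that comparison is confounded by the second difference on the chalcone side, so the evidence is weak. The step to compound 3 is nonetheless expected to be modest and toward a lower number; the expected step reads a 2.0-fold lower number from compound 2 to compound 3 (0.29 log units; within the scatter). Compound 3 is therefore estimated at 3000 nM in this assay, with a range from 1000 nM to 9000 nM.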

Compound 3, concentration for 50% growth inhibition: 6400 nM
The estimate for compound 3 lay 2.1-fold (0.33 log units) below the measured number, and the stated range covers the measured number.
By their numbers in this assay, from the lowest: compound 1; then compounds 2 and 3 (each within the scatter of the next).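

In this assay, the change from 4-methoxyphenyl to 4-chlorophenyl gives a 1.1-fold higher number from compound 2 to compound 3 (0.04 log units; within the scatter), so this single swap at the aromatic carbon para to a large group, read here free of any second difference, produces no separation beyond the scatter. Among these compounds, with the 4-chlorophenyl group held constant, 4-hydroxy-3-methoxyphenyl in place of 3-hydroxyphenyl on the chalcone side gives a 4.2-fold higher number from compound 1 to compound 3 (0.63 log units; beyond the scatter), which places the only single-change step beyond the scatter in this set at that site rather than at the chloro-for-methoxy position. No measurement shown here accounts for either result.

From the compounds shown here alone, the chloro-for-methoxy swap has been read only with the 4-hydroxy-3-methoxyphenyl group in place, so whether it would also stay within the scatter alongside 3-hydroxyphenyl remains open. Also open is whether the position tolerates groups more generally, since an amine or a carboxylic acid on the same aromatic carbon could move the number in either direction, and the two groups shown cannot settle that.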